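A few compounds are considered here, and "the series" means these few. Any claim that something is new, unique, unknown or untested is made for them only; others in the source may bear on it.

Of the compounds shown here, three sharing one core have so far been tested in an ADME assay on Akata cells (Homo sapiens) for cytotoxicity, with a stated time of 7 days (on this read-out lower numbers stand for higher toxicity in this test and higher numbers for lower toxicity in this test), and none gives a number. Compound 3 (`CCCCCOc1nc(N)nc2c1ncn2/C=C1/CC1(CO)CO`) stands at > 20000 nM as a limit and not a number. Compound 1 (`CCCCCCCCOc1nc(N)nc2c1ncn2/C=C1/CC1(CO)CO`) gives > 20000 nM as a limit too. Compound 2 (`CCCCCCCCSc1nc(N)nc2c1ncn2/C=C1/CC1(CO)CO`) gives > 20000 nM as a limit too. Compound 4 (`CCCCCCOc1nc(N)nc2c1ncn2/C=C1/CC1(CO)CO`) has methyl in place of hydrogen on a saturated chain carbon, five bonds along the chain from an oxygen on an aromatic ring. The nearest measured chain change is a step that the two limits leave unreadable from compound 1 to compound 3 and offers no size to carry over, as do a step that the two limits leave unreadable from compound 1 to compound 2 and a step that the two limits leave unreadable from compound 2 to compound 3 alike. What remains is the limit of > 20000 nM in this assay, at which 3 of the 3 values shown sit, and so no step beyond the scatter is expected in this assay in either direction. The expected step is a step that the limit leaves unreadable from compound 3 to compound 4 and it should stay within the scatter. For compound 4 the estimated value is 25000 nM with an expected range from 15000 nM to 50000 nM in this test.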

Compound 4, half-maximal cytotoxic concentration: > 20000 nM
Compound 4 gave a limit, no number; the forecaster's own chance of this, stated with the estimate: 85%; the middle value does not contradict the limit.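

Compound 4 also gives only a limit, not a number, so no step among compounds 1, 2, 3 and 4 can be read in this assay: the limit of > 20000 nM in this assay, at which 4 of the 4 values shown sit.

Where the half-maximal cytotoxic concentration of each compound actually lies, and whether the chain changes shift it, stays open.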